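The source may report more compounds than this note shows. Statements on the series, on what has been measured and on what is new or still open speak of the compounds shown alone.

Working notes on the series. Compound 2 `C=CC(=O)Nc1cc(Nc2nccc(-c3cn(C)c4ccc(F)cc34)n2)c(OC)cc1N(C)CCN(C)C` gives the lowest number of the two measured in a functional assay on A549 cells (Homo sapiens) for antiproliferative activity, read by MTT assay, with a stated time of 72 h (on this read-out higher numbers stand for weaker inhibition and lower numbers for stronger inhibition), at 329 nM. Compound 1 `C=CC(=O)Nc1cc(Nc2nc(C)cc(-c3cn(C)c4ccccc34)n2)c(OC)cc1N(C)CCN(C)C` gives 2910 nM in this assay; compound 1 and compound 2 differ in two places, so their two values show only the gap between them and no single change can be read from it. Compound 3 `C=CC(=O)Nc1cc(Nc2nc(C)cc(-c3cn(C)c4ccc(F)cc34)n2)c(OC)cc1N(C)CCN(C)C` has not been measured in this assay. Its difference from compound 2 is a methyl in place of hydrogen on an aromatic carbon. Within the data shown here, no single step of this kind is available among the measured compounds, so the direction rests on little; a moderate weakening, beyond the scatter but well short of the gap between compound 1 and compound 2, is expected from compound 2 to compound 3, a 2.3-fold higher number from compound 2 to compound 3 (0.36 log units; beyond the scatter). Compound 3 is therefore estimated at 750 nM in this assay, within a range from 250 nM to 2500 nM.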

Compound 3, half-maximal inhibitory concentration: 1490 nM
Estimate against measurement, compound 3: 2.0-fold (0.30 log units) below; measured number inside the range.
By their numbers in this assay, from the lowest: compound 2; then compounds 3 and 1 (each within the scatter of the next).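

Working notes, continued. Among these compounds, at the aromatic carbon next to the ring nitrogen, methyl in place of hydrogen gives a 4.5-fold higher number from compound 2 to compound 3 (0.66 log units; beyond the scatter) in this assay, the first single change that can be read at this position, and here hydrogen carries the lower number. With this methyl present, the fluoro change gives a 2.0-fold lower number from compound 1 to compound 3 (0.29 log units; within the scatter), so that change does not separate these two compounds in this assay. No measurement at hand accounts for the step seen with the methyl.

The compounds shown leave open whether the fluoro change would read the same with hydrogen at this position. They also leave open how this position responds to groups other than methyl, such as a chlorine atom, a methoxy group or an amine.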